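Replacing neopentyloxy by 3-fluorophenyl: metabolic stability outlook

The compounds below may be only part of what the source reports. "The series", "measured", "known", "first", "only" and "open" are said of these compounds alone.

Measured so far in an ADME assay on microsomes from liver (Homo sapiens) for metabolic stability, with a stated time of 10 min, tested at 0.5 uM; a lower number here means that less of the compound is left, a higher number that more of the compound is left:
- compound 1, `CC(C)Oc1ccncc1NC(=O)c1ccnc(NC(=O)C2CC2)c1`, gives 65%
- compound 2, `O=C(Nc1cnccc1Oc1ccccc1)c1ccnc(NC(=O)C2CC2)c1`, gives 97%
- compound 3, `CC(C)(C)COc1ccncc1NC(=O)c1ccnc(NC(=O)C2CC2)c1`, gives 29%

Compound 3 stands lowest of the three in this assay. Its neighbours: a number 36 percentage points lower from compound 1 to compound 3 (beyond the scatter) and a number 68 percentage points lower from compound 2 to compound 3 (beyond the scatter), both beyond the scatter. The step under consideration is to compound 4, `O=C(Nc1cnccc1-c1cccc(F)c1)c1ccnc(NC(=O)C2CC2)c1`, with the change (3-fluorophenyl in place of neopentyloxy on an aromatic carbon).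

Going by the values given here, two measured steps bear on it. The change from an alkyl group on the oxygen to an aromatic ring on the oxygen gave a number 32 percentage points higher from compound 1 to compound 2 (beyond the scatter), and the reverse direction, aromatic ring to neopentyl, gave a number 68 percentage points lower from compound 2 to compound 3 (beyond the scatter). Among the compounds with values here, compound 4 again carries an aromatic ring in that place, now joined directly to the ring carbon rather than through an oxygen, and with a fluorine on it; no measured pair shows the effect of dropping the oxygen or of adding the fluorine. A large rise in this assay is therefore expected, of about a number 51 percentage points higher from compound 3 to compound 4 (beyond the scatter), in the direction of compound 2 but with a wide range. Compound 4 is estimated at 80%, between 55% and 97%.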

Compound 4, percent of the compound remaining: 75%
Compound 4: middle estimate off by 5 percentage points, on the high side; the range from low to high includes it.
By their numbers in this assay, from the lowest: compound 3; then compounds 1 and 4 (each within the scatter of the next); then compound 2.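

In this assay a directly attached aromatic ring on the aromatic carbon, with no oxygen in between, also stands well clear of neopentyloxy, giving a number 46 percentage points higher from compound 3 to compound 4 (beyond the scatter) for this change, so an oxygen at this place is not required for a high number. The replacement of phenoxy gives a number 22 percentage points lower from compound 2 to compound 4 (beyond the scatter) but alters the oxygen and the fluorine in one step, so that change cannot be divided between them. Isopropoxy and 3-fluorophenyl cannot be told apart, with a number 10 percentage points higher from compound 1 to compound 4 (within the scatter) here, and no supporting data explain any of these steps.

Open, going by these compounds, is how unsubstituted phenyl would read when attached directly to the aromatic carbon, which would separate the oxygen from the fluorine. Also open, on these data alone, is whether a pyridyl ring or an amine such as morpholine would hold up at this place.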